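This account rests on a few compounds, and the source may have more. Where it says the series, first, only, none or still open, it means among the compounds named here.

The measured compounds:
Compound 1 `O=C(/C=C\c1cccc(O)c1)N1N=C(c2ccncc2)OC1c1c[nH]c2ccccc12` gives > 30 ug/mL in an ADME assay on PANC-1 cells (Homo sapiens) for cytotoxicity, read by MTT assay, with a stated time of 48 h; on this read-out higher numbers stand for weaker inhibition of growth and lower numbers for stronger inhibition of growth; this is a limit of the assay, not a number.
Compound 2 `O=C(/C=C\c1cccc([N+](=O)[O-])c1)N1N=C(c2ccncc2)OC1c1c[nH]c2ccccc12` gives > 30 ug/mL in this assay; this too is a limit.
Compound 3 `O=C(/C=C\c1ccc([N+](=O)[O-])cc1)N1N=C(c2ccncc2)OC1c1c[nH]c2ccccc12` gives > 30 ug/mL in this assay; this too is a limit.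

In this assay compound 2 stands only at a limit, and the two further values shown are limits as well, so every measured compound sits at the same point, as the limit of > 30 ug/mL in this assay, at which 3 of the 3 values shown sit, records. Compound 4 `O=C(/C=C\c1ccccc1F)N1N=C(c2ccncc2)OC1c1c[nH]c2ccccc12` differs from compound 2 by 2-fluorophenyl in place of 3-nitrophenyl on a double-bonded chain carbon bound to a double-bonded chain carbon.

Three measured steps exist, and none of them can be read: a step that the two limits leave unreadable from compound 1 to compound 2, a step that the two limits leave unreadable from compound 1 to compound 3 and a step that the two limits leave unreadable from compound 2 to compound 3. For the measured compounds named here, they show only that changes on the aromatic ring at this place, from hydroxy to nitro and from one nitro position to another, left every compound beyond the limit. None of them introduces a 2-fluorophenyl group, so the size and direction of the step to compound 4 rest on no measured number.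

Because all three compounds sit at the limit of > 30 ug/mL in this assay, at which 3 of the 3 values shown sit, compound 4 is expected to sit there as well, and no step beyond the scatter is expected in a step that the limit leaves unreadable from compound 2 to compound 4. For compound 4 the estimate in this assay is 45 ug/mL, with a range from 15 ug/mL to 150 ug/mL.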

Compound 4, concentration for 50% growth inhibition: > 30 ug/mL
Compound 4 gave a limit, no number (the forecaster's own chance of this, stated with the estimate: 75%); the middle value does not contradict the limit.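

In this assay compound 4 gives > 30 ug/mL, which is a limit and not a number. None of the steps to compound 4 from compound 1, compound 2 or compound 3 can be read, and all four compounds stand at one point: the limit of > 30 ug/mL in this assay, at which 4 of the 4 values shown sit.

The compounds shown leave open how strongly any of them inhibits growth, and whether any change at this place alters it.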